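The source may report more compounds than this note shows. Statements on the series, on what has been measured and on what is new or still open speak of the compounds shown alone.

Compound 1 `N#Cc1ccc(N2CCN(C(=S)SCc3ccc(C(=O)Nc4ccccc4N)cc3)CC2)cc1` gives 62.9% in a functional assay on A-375 cells (Homo sapiens) for antiproliferative activity, read by CCK-8 assay, with a stated time of 72 h, tested at 8 uM; on this read-out lower numbers stand for a weaker effect and higher numbers for a stronger effect at the one concentration tested.
Compound 2 `Nc1ccccc1NC(=O)c1ccc(CSC(=S)N2CCN(c3ccccc3F)CC2)cc1` gives 79.5% in this assay.

Of these two numbers compound 2 stands highest, and its nearest neighbour is compound 1, with a number 16.6 percentage points higher from compound 1 to compound 2 (beyond the scatter). Compound 3 `Nc1ccccc1NC(=O)c1ccc(CSC(=S)N2CCN(c3cnccn3)CC2)cc1` has not yet been measured; it differs from compound 2 by pyrazin-2-yl in place of 2-fluorophenyl on an amine nitrogen in a ring. Among the compounds with values here, the single measured step swaps a different group on the same ring nitrogen, so it bears on this change only loosely: it shows that changing the group there can move the read-out modestly, but gives no direction for this swap. The expected step is a number 9.5 percentage points lower from compound 2 to compound 3 (within the scatter), likely within the scatter. Compound 3 is estimated at 70%, ranging from 50% to 86%.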

Compound 3, a percentage reported as inhibition, at one concentration (the size of the read-out at that concentration, not a potency): 85.8%
The estimate for compound 3 lay 15.8 percentage points below the measured number, within the range that was stated.
By their numbers in this assay, from the lowest: compound 1; then compounds 2 and 3 (each within the scatter of the next).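

In this assay, an aromatic ring of carbon only proves unnecessary on this ring nitrogen among these compounds: pyrazin-2-yl replaces 2-fluorophenyl with a number 6.3 percentage points higher from compound 2 to compound 3 (within the scatter). Replacing 4-cyanophenyl with pyrazin-2-yl gives a number 22.9 percentage points higher from compound 1 to compound 3 (beyond the scatter), so 4-cyanophenyl stands apart from both other groups. Nothing available explains these differences. Open, from the compounds shown here alone, is whether this nitrogen needs an aromatic ring at all, which a cyclohexyl or a simple methyl group there would test. Also open, going by these compounds, is how an unsubstituted phenyl ring compares with these three groups.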